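Moving the Attachment Point of a Methylimidazole Ring

This account rests on a few compounds, and the source may have more. Where it says the series, first, only, none or still open, it means among the compounds named here.

Going by the values given here, compound 3 `CN1C(=O)N(c2nccn2C)C[C@H]1C(=O)NCc1cccc(C(F)(F)F)c1Cl` gives the lowest number of the three measured so far in a functional assay on HEK293 cells for antagonist activity at P2X purinoceptor 7 (Homo sapiens) (on this read-out lower numbers stand for stronger inhibition and higher numbers for weaker inhibition), at 3.98 nM. Compound 2 `Cc1cc(N2C[C@@H](C(=O)NCc3cccc(C(F)(F)F)c3Cl)N(C)C2=O)ccn1` gives 10 nM in this assay, and compound 1 `CN1CCC(N2C[C@@H](C(=O)NCc3cccc(C(F)(F)F)c3Cl)N(C)C2=O)CC1` gives 31.6 nM. The steps of a 3.2-fold lower number from compound 1 to compound 2 (0.50 log units; beyond the scatter), a 7.9-fold lower number from compound 1 to compound 3 (0.90 log units; beyond the scatter) and a 2.5-fold lower number from compound 2 to compound 3 (0.40 log units; beyond the scatter) show that changing the group on this ring nitrogen shifts the number modestly each time. Compound 4 `CN1C(=O)N(c2cn(C)cn2)C[C@H]1C(=O)NCc1cccc(C(F)(F)F)c1Cl` differs from compound 3 by 1-methyl-1H-imidazol-4-yl in place of 1-methyl-1H-imidazol-2-yl on an amide-type nitrogen in a ring. Among the compounds with values here, no measured step moves the attachment point of the same ring, so those steps give only a sense of scale, and the direction is uncertain. Compound 4 is expected to give about 8 nM, estimated between 2.5 nM and 25 nM. That estimate means an expected step of a 2.0-fold higher number from compound 3 to compound 4 (0.30 log units; within the scatter) in this assay, a modest weakening.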

Compound 4, half-maximal inhibitory concentration: 2.51 nM
Beside the measured number, compound 4's estimate is 3.2-fold (0.50 log units) above it, and the stated range covers the measured number.
By their numbers in this assay, from the lowest: compounds 4 and 3 (each within the scatter of the next); then compound 2; then compound 1.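

Moving the attachment point of the methylimidazole, with the same atoms joined differently, leaves the two isomers indistinguishable (a 1.6-fold lower number from compound 3 to compound 4 (0.20 log units; within the scatter)), so in this assay this position accepts the ring attached either way. Going by these compounds alone, compound 4 also stands clear of the other two groups (a 4.0-fold lower number from compound 2 to compound 4 (0.60 log units; beyond the scatter); a 13-fold lower number from compound 1 to compound 4 (1.10 log units; beyond the scatter)), and the second of these steps is the first large one in this set. No measurement shown here explains these numbers.

From the compounds shown here alone, it stays open how a 1-methyl-1H-imidazol-5-yl group would compare. Also open, going by these compounds, is how a primary amine, a carboxylic acid or a longer chain on this ring nitrogen would fare.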